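Extending the chain alpha to the acid in a DP2 antagonist series

The compounds below may be only part of what the source reports. "The series", "measured", "known", "first", "only" and "open" are said of these compounds alone.

In an assay on CHO cells for displacement of a labelled ligand from prostaglandin D2 receptor 2 (Homo sapiens), read by scintillation counting (on this read-out lower numbers stand for stronger inhibition and higher numbers for weaker inhibition), three compounds of a shared core have been measured. Compound 1 `CN(C)S(=O)(=O)c1ccc(F)c(C#Cc2cc(Cl)ccc2OCC(=O)O)c1` gives 3.1 nM, compound 2 `CCCS(=O)(=O)c1ccc(C)c(C#Cc2cc(Cl)ccc2OC(C)C(=O)O)c1` gives 1.2 nM, and compound 3 `CCCS(=O)(=O)c1ccc(F)c(C#Cc2cc(Cl)ccc2OC(C)C(=O)O)c1` gives 3 nM. Compound 2 has the lowest number of the three: its nearest neighbour is compound 3, and the step of a 2.5-fold higher number from compound 2 to compound 3 (0.40 log units; beyond the scatter) is beyond the scatter, while the gap to compound 1 is of the same order and likewise beyond the scatter. Compound 1 and compound 3 differ in more than one place, so their two values only show that both lie close together.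

Compound 4 `CCCS(=O)(=O)c1ccc(C)c(C#Cc2cc(Cl)ccc2OC(CC)C(=O)O)c1` differs from compound 2 by methyl in place of hydrogen on a saturated chain carbon, two bonds along the chain from a carbonyl carbon and an oxygen on an aromatic ring. Among the compounds with values here, none of the measured steps touches this position: the only single-point step, from compound 2 to compound 3, concerns a fluoro in place of methyl on an aromatic carbon and says nothing about the chain. With no comparable precedent among these compounds, the expectation for this assay is a step of no clear size beyond the scatter, with its direction left open, which is a 1.3-fold higher number from compound 2 to compound 4 (0.10 log units; within the scatter). Compound 4 is therefore estimated at 1.5 nM, within a range from 0.5 nM to 5 nM.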

Compound 4, inhibition constant: 30 nM
Compound 4: middle estimate off by 20-fold (1.30 log units), on the low side; measured number above the stated range.
By their numbers in this assay, from the lowest: compound 2; then compounds 3 and 1 (each within the scatter of the next); then compound 4.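

In this assay, the saturated chain carbon two bonds along the chain from a carbonyl carbon and an oxygen on an aromatic ring proves highly sensitive: replacing 1-carboxyethoxy with 1-carboxypropoxy gives a 25-fold higher number from compound 2 to compound 4 (1.40 log units; beyond the scatter) and is the largest step shown, well beyond the scatter. The change adds only 1 heavy atom, a methyl with no ring and no hydrogen-bond donors or acceptors, yet this step far exceeds the one on the aromatic carbon, a 2.5-fold higher number from compound 2 to compound 3 (0.40 log units; beyond the scatter), so the chain position matters more here than that aromatic position does. Nothing in the material shown bears on why the number rises so steeply at this position.

On these data alone, it remains open whether a longer chain such as propyl, a branched group such as isopropyl or a ring such as cyclopropyl on the same carbon would raise the number further, or whether ethyl already marks the limit of what this position accepts. As far as these compounds go, it is also open whether the same methyl-for-hydrogen change would give a step of similar size with fluoro in place of methyl on the aromatic carbon, as in compound 3.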